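This account rests on a few compounds, and the source may have more. Where it says the series, first, only, none or still open, it means among the compounds named here.

Of the compounds shown here, two have been measured in a physicochemical assay for lipophilicity; a higher number here means a more lipophilic compound, a lower number a more polar compound. Compound 1, `C[C@H]1CC[C@@H]2[C@@H](OC(=O)[C@]23CC(c2ccc(N(C)C)cc2)=NO3)[C@]2(C)C(=O)C=C[C@@]12O`, gives 1.51. Compound 2, `Cc1ccc(C2C[C@@]3(ON2c2ccccc2)C(=O)O[C@@H]2[C@H]3CC[C@H](C)[C@]3(O)C=CC(=O)[C@@]23C)cc1`, gives 3.64, the higher of the two numbers, and the gap between compound 2 and compound 1 lies beyond the usual scatter of repeated measurements of this kind. Compound 3, `C[C@H]1CC[C@@H]2[C@@H](OC(=O)[C@]23CC(c2c(F)c(F)c(F)c(F)c2F)N(c2ccccc2)O3)[C@]2(C)C(=O)C=C[C@@]12O`, has not yet been measured in this assay. It differs from compound 2 in one place: 2,3,4,5,6-pentafluorophenyl in place of 4-methylphenyl on a saturated ring carbon. Among the measured compounds shown here, no two measured compounds here differ by a single change, so there is no measured step to lean on for this exchange. The step expected from compound 2 to compound 3 is a small one, leaning slightly upward, and most likely within the scatter: a number 0.16 log units higher from compound 2 to compound 3 (within the scatter). Compound 3 is therefore estimated at 3.8 in this assay, with a range from 3.2 to 4.5.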

Compound 3, partition coefficient: 3.72
Compound 3: the middle estimate sits 0.08 log units above what was measured; low and high end bracket the measured number.
By their numbers in this assay, from the lowest: compound 1; then compounds 2 and 3 (each within the scatter of the next).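

In this assay, this exchange on the saturated ring carbon gives a number 0.08 log units higher from compound 2 to compound 3 (within the scatter), the first single change measured at this place. Although the entering group has more heavy atoms and brings in five fluorine atoms, the two compounds cannot be told apart in this assay, so this particular swap of one aromatic ring for another leaves the reading unresolved from the scatter. Nothing measured here explains why the two groups read alike.

As far as these compounds go, both groups are aromatic carbon rings with no hydrogen-bond donors, no hydrogen-bond acceptors and no net charge, so it remains open how this assay would respond at this place to a different kind of group, such as a carboxylic acid or a primary amine. Compound 1 differs from compound 2 in more than one place, so its gap cannot be assigned to any single part of the structure.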